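Series notes: chloro on the aryl ether ring of compound 1

A few compounds are considered here, and "the series" means these few. Any claim that something is new, unique, unknown or untested is made for them only; others in the source may bear on it.

Measured so far:
compound 1, `CCC(CC)n1c(-c2ccc(OCc3c(-c4c(Cl)cccc4Cl)noc3C(C)C)cc2)nc2ccc(C(=O)O)cc21`, 0.8 nM
compound 2, `CCn1c(-c2ccc(OCc3c(-c4c(Cl)cccc4Cl)noc3C(C)C)cc2)nc2ccc(C(=O)O)cc21`, 2.31 nM
compound 3, `CC(C)c1onc(-c2c(Cl)cccc2Cl)c1COc1ccc(-c2nc3ccc(C(=O)O)cc3n2CC2CC2)cc1`, 19.4 nM

In an assay on Huh-7 cells for agonist activity at Bile acid receptor (Homo sapiens), read by a luciferase reporter (a lower number here means that less compound is needed, a higher number that more compound is needed for the effect), compound 1 gives the lowest of the three numbers. Its nearest neighbour is compound 2, a 2.9-fold higher number from compound 1 to compound 2 (0.46 log units; beyond the scatter); the furthest is compound 3, a 24-fold higher number from compound 1 to compound 3 (1.38 log units; beyond the scatter). Between the other two the step is an 8.4-fold higher number from compound 2 to compound 3 (0.92 log units; beyond the scatter). All three measured steps concern the group on the aromatic nitrogen of the shared core.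

Compound 4, `CCC(CC)n1c(-c2ccc(OCc3c(-c4c(Cl)cccc4Cl)noc3C(C)C)cc2Cl)nc2ccc(C(=O)O)cc21`, keeps the pentan-3-yl of compound 1 and differs from it elsewhere: chloro in place of hydrogen on an aromatic carbon.

Among the compounds with values here, none of the measured steps touches this ring, so no step bears directly on the change. The shared core and the pentan-3-yl of compound 1 are kept, so the expectation is no step beyond the scatter in this assay, in either direction. Compound 4 is therefore expected to give 1 nM, within a range of 0.4 nM to 3 nM, meaning an estimated step of a 1.3-fold higher number from compound 1 to compound 4 (0.10 log units; within the scatter).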

Compound 4, half-maximal effective concentration: 1.6 nM
Beside the measured number, compound 4's estimate is 1.6-fold (0.20 log units) below it; low and high end bracket the measured number.
By their numbers in this assay, from the lowest: compounds 1, 4 and 2 (each within the scatter of the next, the first and the last beyond it); then compound 3.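

In this assay, chloro in place of hydrogen on an aromatic carbon, ortho to a large group and meta to a large group, gives a 2.0-fold higher number from compound 1 to compound 4 (0.30 log units; within the scatter). This is the first change shown away from the group on the aromatic nitrogen, and unlike the steps at that nitrogen, it stays within the scatter, so this ring position takes a chloro with the pentan-3-yl kept. Nothing available bears on what lies behind this result.

Open, going by these compounds, is whether a larger or different group at this ring position, such as methoxy, trifluoromethyl or an amine, would also stay within the scatter. Also open, on these data alone, is whether the chloro behaves in the same way with the ethyl of compound 2 or the cyclopropylmethyl of compound 3 on the aromatic nitrogen.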